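The source may hold more compounds than are shown below. What is called first, only, known or untested is meant among the compounds shown, and "the series" means these compounds.

In an assay on isolated protein for inhibition of proto-oncogene tyrosine-protein kinase receptor Ret (Homo sapiens), read by mobility shift assay, with a stated time of 1 h, tested at 10 uM (on this read-out higher numbers stand for more inhibition at the one concentration tested (going by the name of the read-out) and lower numbers for less inhibition), compound 1 `CN(C)CCn1cnnc1-c1cc(Oc2ccc(NC(=O)Nc3cccc(C(F)(F)F)c3)cc2F)ccn1` gives 77.7%, while compound 2 `CN(C)CCn1cnnc1-c1cc(Oc2ccc(NC(=O)Nc3ccc(F)c(Cl)c3)cc2F)ccn1` gives 63.3%. Among the measured compounds shown here, the only measured step is a number 14.4 percentage points lower from compound 1 to compound 2 (beyond the scatter). In this assay compound 3 `CN(C)CCn1cnnc1-c1cc(Oc2ccc(NC(=O)Nc3ccc(Cl)cc3Cl)cc2F)ccn1` gives "not determined" (no result reported), so no number is reported for it. Compound 2 therefore holds the lower of the two numbers shown, with compound 1 the nearest entry and the gap between them beyond the scatter. Compound 4 `CN(C)CCCn1cnnc1-c1cc(Oc2ccc(NC(=O)Nc3ccc(F)c(Cl)c3)cc2F)ccn1` differs from compound 2 by (dimethylamino)methyl in place of dimethylamino on a saturated chain carbon, two bonds along the chain from an aromatic nitrogen. No measured step touches this part of the molecule: the step from compound 1 to compound 2 changes the group on the amide-type nitrogen instead, so nothing shown indicates a direction here. Compound 4 is thus expected to stay close to compound 2, with an expected step of a number 3.3 percentage points lower from compound 2 to compound 4 (within the scatter) and an estimated 60% in the range 40% to 80%.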

Compound 4, a percentage reported as inhibition, at one concentration (the size of the read-out at that concentration, not a potency): 45.5%
Compound 4: the middle estimate sits 14.5 percentage points above what was measured; measured number inside the range.
By their numbers in this assay, from the lowest: compound 4; then compound 2; then compound 1.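

Going from 2-(dimethylamino)ethyl to 3-(dimethylamino)propyl gives, in this assay, a number 17.8 percentage points lower from compound 2 to compound 4 (beyond the scatter) and beyond the scatter. This shows that the read-out also responds at this chain position, which the earlier step on the amide-type nitrogen left untouched. No measured evidence bears on the reason for this drop.

Going by these compounds, whether a butyl chain, or morpholine or pyrrolidine in place of dimethylamino, would raise or lower the number remains open. So does whether the longer chain has the same outcome alongside the 3-(trifluoromethyl)phenyl group of compound 1.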